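The source may report more compounds than this note shows. Statements on the series, on what has been measured and on what is new or still open speak of the compounds shown alone.

In a functional assay on HeLa cells (Homo sapiens) for inhibition, read by MTT assay, with a stated time of 48 h (on this read-out lower numbers stand for stronger inhibition and higher numbers for weaker inhibition), compound 1 `Cc1cc(OCc2cn(-c3ccc(NS(C)(=O)=O)c(Oc4ccccc4)c3)nn2)ccc1Cl` gives 7900 nM. Within the data shown here, for compound 2 `CS(=O)(=O)Nc1ccc(-n2cc(COc3ccc([N+](=O)[O-])cc3)nn2)cc1Oc1ccccc1` the entry in this assay reads "not determined" (no result reported), and for compound 3 `Cc1ccc(-c2cn(-c3ccc(NS(C)(=O)=O)c(Oc4ccccc4)c3)nn2)cc1` it likewise reads "not determined" (no result reported), so compound 3 stands without a number, beside one further compound that also lacks one, against the single measured value of compound 1. Compound 4 `CS(=O)(=O)Nc1ccc(-n2cc(COc3ccccc3Cl)nn2)cc1Oc1ccccc1` arises from compound 3 through the change ((2-chlorophenoxy)methyl in place of 4-methylphenyl on an aromatic carbon), placed on an aromatic carbon of a five-membered aromatic ring with 3 nitrogen. Among the measured compounds shown here, no step between measured compounds is known, and compound 3 carries no value, so the size and direction of the step to compound 4 in this assay cannot be set from a measured pair; the expectation leans on compound 1, whose 7900 nM is the only anchor. Compound 4 is estimated at 8000 nM, with a range from 2000 nM to 30000 nM.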

Compound 4, half-maximal inhibitory concentration: 38600 nM
Estimate against measurement, compound 4: 4.8-fold (0.68 log units) below; the measured number lies above the stated range.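

In this assay the change to 2-chlorophenyl in place of 4-chloro-3-methylphenyl on the oxygen gives a 4.9-fold higher number from compound 1 to compound 4 (0.69 log units; beyond the scatter) and so shows that the aryl group at this place moves the number, with compound 4 the weaker of the pair. The step from compound 3 to compound 4 cannot be read. No evidence bearing on the cause of this shift is at hand. Open remains how an amine or a carboxylic acid on that phenyl ring would compare, and whether (2-chlorophenoxy)methyl in place of 4-methylphenyl changes the number at all.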